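A few compounds are considered here, and "the series" means these few. Any claim that something is new, unique, unknown or untested is made for them only; others in the source may bear on it.

Of the compounds shown here, two from this series have been measured so far. Compound 1, `COc1ccc(-c2[nH]c3ccccc3c2/C=C(\C#N)S(=O)(=O)c2ccccc2)cc1`, gives 682 nM in a functional assay on Hs-578T cells (Homo sapiens) for inhibition, read by sulforhodamine B assay, with a stated time of 48 h; a lower number here means a stronger inhibitor of growth, a higher number a weaker inhibitor of growth. Compound 2, `CC(=O)/C(=C\c1c(-c2ccccc2)[nH]c2ccccc12)S(=O)(=O)c1ccccc1`, gives 5000 nM in this assay, the higher of the two numbers, and the gap to compound 1 lies beyond the usual scatter. Among the compounds with values here, compound 1 and compound 2 differ in more than one place, so their two values show only that compound 2 is the weaker growth inhibitor of the pair, and nothing can be attributed to any single part of the structure.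

Compound 3, `O=C(/C(=C\c1c(-c2ccccc2)[nH]c2ccccc12)S(=O)(=O)c1ccccc1)c1ccccc1`, has not yet been measured. It differs from compound 2 by phenyl in place of methyl on a carbonyl carbon. Within the data shown here, nothing among the measured compounds speaks to this particular change, so the direction of its effect is open. The expectation is a step from compound 2 to compound 3 that is small and possibly within the scatter, with a slight lean toward a lower number, a 1.4-fold lower number from compound 2 to compound 3 (0.15 log units; within the scatter). On that basis compound 3 is estimated to give 3500 nM in this assay, most likely somewhere between 1000 nM and 12000 nM.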

Compound 3, concentration for 50% growth inhibition: 39500 nM
Compound 3: middle estimate off by 11-fold (1.05 log units), on the low side, outside the stated range (above it).
By their numbers in this assay, from the lowest: compound 1; then compound 2; then compound 3.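

Replacing acetyl with benzoyl on this carbonyl carbon gives a 7.9-fold higher number from compound 2 to compound 3 (0.90 log units; beyond the scatter) in this assay and so marks compound 3 as the weaker growth inhibitor of the two. Within the data shown here, this is the first single-place comparison in the set, and it shows that the group on this carbonyl carbon matters: the result is sensitive to exchanging one carbon for a six-membered aromatic ring, something compound 1 and compound 2 could not show because they differ in more than one place. No measurement at hand accounts for the change, so it stands as an observation, and which feature of the phenyl ring is responsible remains unsettled.

The compounds shown leave open how the number would respond to other groups on this carbonyl carbon, such as a longer chain like propyl or an amine that would turn the ketone into an amide. They also leave open how any of these ketones would compare with a nitrile at this place on an otherwise identical structure, since compound 1 carries a nitrile but also differs elsewhere.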